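From phenylsulfonyl to (4-fluorophenyl)sulfonyl in compound 2

The compounds below may be only part of what the source reports. "The series", "measured", "known", "first", "only" and "open" are said of these compounds alone.

Compound 1 `O=C1/C(=C/c2cccnc2)CN(S(=O)(=O)c2ccccc2)C/C1=C\c1ccccc1F` gives 19100 nM
Compound 2 `O=C1/C(=C/c2cccnc2)CN(S(=O)(=O)c2ccccc2)C/C1=C\c1ccccc1C(F)(F)F` gives 10900 nM

Among the compounds with values here, in a functional assay on SMMC-7721 cells (Homo sapiens) for cytotoxicity, read by MTT assay, with a stated time of 24 h (a higher number here means a weaker inhibitor, a lower number a stronger inhibitor), compound 2 stands within the scatter of compound 1, the only other compound measured, so the two cannot be ranked. Compound 3 `O=C1/C(=C/c2cccnc2)CN(S(=O)(=O)c2ccc(F)cc2)C/C1=C\c1ccccc1C(F)(F)F` departs from compound 2 at the phenylsulfonyl group alone, which becomes (4-fluorophenyl)sulfonyl, and the difference counts as fluoro in place of hydrogen on an aromatic carbon in all. In words, this is fluoro in place of hydrogen on an aromatic carbon, para to a large group.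

Within the data shown here, only one measured step is available as a guide. It is a 1.8-fold lower number from compound 1 to compound 2 (0.24 log units; within the scatter) and it comes from trifluoromethyl in place of fluoro on an aromatic carbon. That step concerns a different group, and no change at the phenylsulfonyl group has been measured, so it bears on compound 3 only loosely. With compound 2 at 10900 nM as the starting point, no shift beyond the scatter is expected in this assay for this change.

The estimated step is a 1.1-fold lower number from compound 2 to compound 3 (0.04 log units; within the scatter) and it carries no firm direction. For compound 3 the expected value is 10000 nM within an estimated range from 4500 nM to 22000 nM as the likely span.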

Compound 3, half-maximal inhibitory concentration: 6390 nM
Estimate against measurement, compound 3: 1.6-fold (0.19 log units) above; the measured number falls inside the stated range.
By their numbers in this assay, from the lowest: compounds 3, 2 and 1 (each within the scatter of the next, the first and the last beyond it).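

In this assay, the step at the sulfonyl end of the molecule reads a 1.7-fold lower number from compound 2 to compound 3 (0.23 log units; within the scatter), so placing fluoro on the aromatic ring of the phenylsulfonyl group, para to a large group, gives no shift that can be told apart from repeat measurements, and compound 2 and compound 3 cannot be ranked. Within the data shown here, this is the first reading at this part of the molecule, since the earlier pair differed only on the other aromatic ring, where trifluoromethyl takes the place of fluoro, and it shows that a single fluoro can be carried on the phenylsulfonyl group with the number still in the same range as that of compound 2. No measurement accompanies these compounds that could explain this result or say how the compounds act on these cells.

From the compounds shown here alone, whether a group larger than fluoro at this position, such as methoxy, an amine or a carboxylic acid, would separate clearly from compound 2 remains open. Also open, going by these compounds, is whether the same fluoro gives a similar reading when the other aromatic ring carries fluoro, as in compound 1, rather than trifluoromethyl.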